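Series notes: compound 2 to compound 3 in thromboxane synthase inhibition

The source may report more compounds than this note shows. Statements on the series, on what has been measured and on what is new or still open speak of the compounds shown alone.

For the measured compounds named here, compound 2 `COc1ccc(COCC(Cn2ccnc2)OCc2ccc([S+](C)[O-])cc2)cc1` gives 8600 nM in a functional assay for inhibition of Thromboxane-A synthase (Homo sapiens) (on this read-out higher numbers stand for weaker inhibition and lower numbers for stronger inhibition), the higher of the two numbers measured so far; compound 1 `COc1ccc(COCC(Cn2ccnc2)OCc2ccc(C(=O)OCc3ccccc3)cc2)cc1` gives 1490 nM in this assay. Compound 3 `COc1ccc(COCC(Cn2ccnc2)OCc2ccc(S(C)(=O)=O)cc2)cc1` differs from compound 2 by a group of 4 heavy atoms (1 carbon, 2 oxygen, 1 sulfur; no ring) in place of a group of 3 heavy atoms (1 carbon, 1 oxygen, 1 sulfur; no ring), on an aromatic carbon. Going by the values given here, the only measured step, a 5.8-fold higher number from compound 1 to compound 2 (0.76 log units; beyond the scatter), concerns a different and much larger exchange on the same aromatic carbon, so no measured step bears directly on this change. Without a directly comparable step, the expectation for compound 3 in this assay is a step of a 1.2-fold lower number from compound 2 to compound 3 (0.09 log units; within the scatter), not beyond the scatter. Compound 3 is therefore estimated at 7000 nM, within a range of 2500 nM to 20000 nM.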

Compound 3, half-maximal inhibitory concentration: 24900 nM
Compound 3: the middle estimate sits 3.6-fold (0.55 log units) below what was measured; the whole stated range lies below it.
By their numbers in this assay, from the lowest: compound 1; then compound 2; then compound 3.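

In this assay, the exchange for methylsulfonyl on this aromatic carbon gives a 2.9-fold higher number from compound 2 to compound 3 (0.46 log units; beyond the scatter) and so shows that even a small change between sulfur-bearing groups here moves the number beyond the scatter. Set against benzyloxycarbonyl, the same group gives a 17-fold higher number from compound 1 to compound 3 (1.22 log units; beyond the scatter) and stands as the weakest of the three groups seen at this position. No measurement at hand accounts for either step.

Still open, as far as these compounds go, is whether the lower number with benzyloxycarbonyl depends on its carbonyl or on its benzyl ring. A carboxylic acid or a methyl ester on this carbon would bear on that question.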